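The source may report more compounds than this note shows. Statements on the series, on what has been measured and on what is new or still open speak of the compounds shown alone.

Measured in an assay on CHO cells for displacement of a labelled ligand from adenosine receptor A3 (Homo sapiens), read by scintillation counting, tested at 10 uM; a higher number here means more inhibition at the concentration tested (going by the name of the read-out), a lower number less inhibition:

Compound 1, `CC(C)Cc1csc(N)c1C(=O)c1ccc(Cl)cc1`: 1%
Compound 2, `CC(C)(C)c1csc(N)c1C(=O)c1ccc(Cl)cc1`: 1%
Compound 3, `CC(C)(C)Cc1csc(N)c1C(=O)c1ccc(Cl)cc1`: 5%

Compound 3 holds the highest of the three numbers, with compound 1 nearest and compound 2 furthest, yet both gaps lie within the scatter, so no order among the three can be claimed. The three measured steps, no change at the digits printed from compound 1 to compound 2 (within the scatter), a number 4 percentage points higher from compound 1 to compound 3 (within the scatter) and a number 4 percentage points higher from compound 2 to compound 3 (within the scatter), all concern the alkyl group on the shared core, and none of them leaves the scatter. Compound 4, `CC(C)(C)Cc1c(-c2ccncc2)sc(N)c1C(=O)c1ccc(Cl)cc1`, differs from compound 3 at another place: pyridin-4-yl in place of hydrogen on an aromatic carbon. Within the data shown here, no measured step touches this position, so the steps give no direct guide to the size or direction of the change. What they do show is that each change so far has left the read-out within the scatter, and the expectation for this assay is therefore a step of a number 3 percentage points higher from compound 3 to compound 4 (within the scatter), expected to remain within the scatter. Compound 4 is estimated at 8%, within a range from 0% to 25%.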

Compound 4, a percentage reported as inhibition, at one concentration (the size of the read-out at that concentration, not a potency): 6%
Beside the measured number, compound 4's estimate is 2 percentage points above it; the measured number falls inside the stated range.
By their numbers in this assay, from the lowest: compounds 1, 2, 3 and 4 (each within the scatter of the next).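

Among these compounds, the step at the aromatic carbon next to the ring sulfur is the first measured change at this position: in this assay, pyridin-4-yl in place of hydrogen gives a number 1 percentage points higher from compound 3 to compound 4 (within the scatter). Adding this aromatic ring therefore leaves the read-out within the scatter, as the changes among the alkyl groups did, so this position too has shown no measurable effect on the number. Nothing available explains this result.

From the compounds shown here alone, it remains open whether another group at this position, such as phenyl, an amine or a carboxylic acid, would carry the number beyond the scatter. Going by these compounds, it is also open whether any change elsewhere on the shared core would do so, such as a methyl group on the amino group or a methoxy group in place of the chlorine.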